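Removing the Methoxymethyl Group: Expected Clearance of Compound 4

The compounds below may be only part of what the source reports. "The series", "measured", "known", "first", "only" and "open" are said of these compounds alone.

Compound 1, `COC[C@@H]1C[C@@H](C(=O)NCC2CCOCC2)CN(Cc2nc(-c3ccccc3)oc2C)C1`: 239 mL.min-1.g-1
Compound 3, `COC[C@@H]1C[C@@H](C(=O)NC[C@H]2CCCO2)CN(Cc2nc(-c3ccccc3)oc2C)C1`: 233 mL.min-1.g-1
Compound 2, `Cc1oc(-c2ccccc2)nc1CN1C[C@H](C(=O)NCc2cccc(N)n2)C[C@@H](c2ccccc2)C1`: reaches only the assay limit of > 300 mL.min-1.g-1

In an in vitro ADME assay on microsomes from liver (Homo sapiens) for metabolic stability (on this read-out lower numbers stand for slow clearance and higher numbers for fast clearance), compound 3 gives 233 mL.min-1.g-1. Compound 1 gives 239 mL.min-1.g-1, and the two numbers lie within the usual scatter of each other. Compound 2 reports only a limit, the one described by the limit of > 300 mL.min-1.g-1 in this assay, at which 1 of the 3 values shown sits. Compound 4, `Cc1oc(-c2ccccc2)nc1CN1CCC[C@@H](C(=O)NC[C@H]2CCCO2)C1`, is not yet measured; it differs from compound 3 by hydrogen in place of methoxymethyl on a saturated ring carbon. For the measured compounds named here, the only measured step, a 1.0-fold lower number from compound 1 to compound 3 (0.01 log units; within the scatter), alters a different part of the molecule and gives no guide to this change, so compound 4 is expected to stay close to compound 3, with an estimated step of a 1.0-fold lower number from compound 3 to compound 4 (0.01 log units; within the scatter) in this assay. Compound 4 is therefore estimated at 230 mL.min-1.g-1, between 110 mL.min-1.g-1 and 300 mL.min-1.g-1.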

Compound 4, intrinsic clearance in microsomes: 84 mL.min-1.g-1
The estimate for compound 4 lay 2.7-fold (0.44 log units) above the measured number, and the stated range ends above it.
By their numbers in this assay, from the lowest: compound 4; then compounds 3 and 1 (each within the scatter of the next). At a limit, above all of these: compound 2.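

Hydrogen in place of methoxymethyl on this saturated ring carbon gives a 2.8-fold lower number from compound 3 to compound 4 (0.44 log units; beyond the scatter) in this assay, whereas the earlier change on the amide side stayed within the scatter. This pair therefore shows that a change at this ring carbon can shift clearance, which compounds 1 and 3 could not reveal, as both carry methoxymethyl there. Nothing measured here explains why the number falls.

The compounds shown leave open how a methyl, a hydroxymethyl or an amine on this ring carbon would compare with hydrogen and methoxymethyl. They also leave open whether the same change would give a similar step with oxan-4-yl in place of oxolan-2-yl.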